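Adding One Methyl to the Chain of Compound 2

The compounds below may be only part of what the source reports. "The series", "measured", "known", "first", "only" and "open" are said of these compounds alone.

In a functional assay on cells (T-cell line, Homo sapiens) for inhibition (a lower number here means a stronger inhibitor, a higher number a weaker inhibitor), compound 1 `Cc1ccc(CCCN2CCC(COC(c3ccccc3)c3ccccc3)CC2)cc1` gives 200 nM, while compound 2 `CCCCCCN1CCC(COC(c2ccccc2)c2ccccc2)CC1` gives 5500 nM, the higher of the two numbers and so the weaker inhibitor. Compound 3 `CCCCCCCN1CCC(COC(c2ccccc2)c2ccccc2)CC1` differs from compound 2 by methyl in place of hydrogen on a saturated chain carbon, six bonds along the chain from an amine nitrogen in a ring: methyl in place of hydrogen, six bonds along the chain from the ring amine nitrogen. Among the measured compounds shown here, the one measured step, a 28-fold higher number from compound 1 to compound 2 (1.44 log units; beyond the scatter), is large, but it exchanges 4-methylphenyl for propyl and is only a loose guide to a single methyl. Only a small shift toward a lower number is therefore expected, and the estimated step is a 1.6-fold lower number from compound 2 to compound 3 (0.20 log units; within the scatter). Compound 3 is expected at 3500 nM, within an estimated range of 1200 nM to 9000 nM.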

Compound 3, half-maximal inhibitory concentration: 500 nM
Compound 3: middle estimate off by 7.0-fold (0.85 log units), on the high side; the whole stated range lies above it.
By their numbers in this assay, from the lowest: compound 1; then compound 3; then compound 2.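

In this assay, methyl in place of hydrogen, six bonds along the chain from an amine nitrogen in a ring, gives a large change, an 11-fold lower number from compound 2 to compound 3 (1.04 log units; beyond the scatter). This position therefore responds strongly to a single added carbon, and the remaining difference in the chain, with butyl in place of 4-methylphenyl, is much smaller, a 2.5-fold higher number from compound 1 to compound 3 (0.40 log units; beyond the scatter). No measurement here explains why one methyl matters so much. As far as these compounds go, whether a longer chain would lower the number further remains open, and so does the effect of a hydroxyl or an amine at the same place.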